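Ethoxycarbonyl for trifluoromethyl, compound 2 to compound 3

The compounds below may be only part of what the source reports. "The series", "measured", "known", "first", "only" and "open" are said of these compounds alone.

Measured in a functional assay on Caco-2 cells (Homo sapiens) for antiproliferative activity, with a stated time of 48 h; on this read-out lower numbers stand for stronger inhibition and higher numbers for weaker inhibition:
- compound 1 `COc1ccc(Nc2ccc(-c3ccccc3)nn2)cc1`: 50000 nM
- compound 2 `CCN(CC)c1ccc(-c2cccc(C(F)(F)F)c2)nn1`: > 25000 nM (a limit, not a number)

Compound 2 gives no number: its entry is the limit of > 25000 nM in this assay, at which 1 of the 2 values shown sits. Compound 3 `CCOC(=O)c1cccc(-c2ccc(N(CC)CC)nn2)c1` carries ethoxycarbonyl in place of trifluoromethyl on an aromatic carbon. For the measured compounds named here, no measured step between compounds differing in one place is available, so the size of this change in this assay is unknown. No step beyond the scatter is expected, and the expectation leans on compound 1 at 50000 nM. The estimated change is a step that the limit leaves unreadable from compound 2 to compound 3. Compound 3 is estimated at 35000 nM, with an expected range of 15000 nM to 80000 nM.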

Compound 3, half-maximal inhibitory concentration: > 25000 nM
Compound 3 was reported as a limit; the forecaster's own chance of this, stated with the estimate: 55%; the middle value does not contradict the limit.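

No step from compound 2 to compound 3 can be read, since both entries are limits: the limit of > 25000 nM in this assay, at which 2 of the 3 values shown sit.

The compounds shown leave open how ethoxycarbonyl and trifluoromethyl compare on the shared core in this assay.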